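This account rests on a few compounds, and the source may have more. Where it says the series, first, only, none or still open, it means among the compounds named here.

For the measured compounds named here, in a functional assay on MDA-MB-231 cells (Homo sapiens) for cytotoxicity, read by MTT assay, with a stated time of 72 h (a higher number here means a weaker inhibitor, a lower number a stronger inhibitor), compound 1 `Cn1nc(-c2ccccc2)c2cc(C(=N)Nc3ccccc3)ncc21` gives 11100 nM and compound 2 `COc1ccc(Cn2nc(-c3ccccc3)c3cc(C(=N)Nc4ccccc4)ncc32)cc1` gives 5400 nM, the lower of the two numbers measured so far. Placing 4-methoxyphenyl in place of hydrogen on a saturated chain carbon bound to an aromatic nitrogen gave a 2.1-fold lower number from compound 1 to compound 2 (0.31 log units; beyond the scatter). Compound 3 `COc1ccc(Cn2nc(-c3ccccc3)c3cc(C(=N)Nc4cccc(C(F)(F)F)c4)ncc32)cc1` reaches only a limit of this assay, at > 50000 nM. Trifluoromethyl in place of hydrogen on an aromatic carbon gave an at least 9.2-fold higher number from compound 2 to compound 3 (0.96 log units; beyond the scatter).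

Compound 4 `COc1ccc(Cn2ncc3cc(C(=N)Nc4ccccc4)ncc32)cc1` is the next to be measured, and its difference from compound 2 is hydrogen in place of phenyl on an aromatic carbon. In words, it carries hydrogen in place of phenyl on an aromatic carbon. Neither measured step touches that place, so neither can be carried over directly. They show only that a single change among these compounds has moved the number beyond the scatter, modestly in the one case and at least modestly in the other. Compound 2 starts from the lowest number at 5400 nM, so a modest rise is expected, though the direction remains uncertain. The estimated change is a 2.6-fold higher number from compound 2 to compound 4 (0.41 log units; beyond the scatter). For compound 4 the expected value is 14000 nM, with an estimated range from 4500 nM to 45000 nM.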

Compound 4, half-maximal inhibitory concentration: 34700 nM
Compound 4: middle estimate off by 2.5-fold (0.39 log units), on the low side; low and high end bracket the measured number.
By their numbers in this assay, from the lowest: compound 2; then compound 1; then compound 4. At a limit, above all of these: compound 3.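

In this assay, for the compounds shown here, this is the first change at the aromatic carbon of the five-membered aromatic ring with 2 nitrogen, and hydrogen in place of phenyl gave a 6.4-fold higher number from compound 2 to compound 4 (0.81 log units; beyond the scatter). The earlier steps shown here touched only the group on the ring nitrogen and the trifluoromethyl position, so the result adds a third place where a single change moves the number beyond the scatter, and it shows that, in this pair, losing the phenyl raises the number rather than leaving it unchanged. Nothing measured here accounts for the size or direction of this step.

With only phenyl and hydrogen at this place, the compounds shown leave open whether a methyl, a longer chain, a pyridine ring or a phenyl carrying a methoxy or an amine would give a number nearer to that of compound 2 or further from it. They also leave open whether the same exchange would move the number in the same direction with the methyl of compound 1 on the ring nitrogen in place of the 4-methoxybenzyl group.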